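Fluoro in Place of Amino: Compound 1 to Compound 3

A few compounds are considered here, and "the series" means these few. Any claim that something is new, unique, unknown or untested is made for them only; others in the source may bear on it.

Measured so far:
compound 1, `COc1cc(O)ccc1/C=C/C(=O)c1ccc(N)cc1`: 0.8%
compound 2, `COc1ccc(/C=C/C(=O)c2ccc(O)cc2O)cc1Br`: 73.2%

Of the compounds shown here, two have been measured in an assay on isolated protein for inhibition of DNA topoisomerase 1 (Homo sapiens), tested at 100 uM; on this read-out higher numbers stand for a stronger effect at the one concentration tested and lower numbers for a weaker effect. Compound 1 `COc1cc(O)ccc1/C=C/C(=O)c1ccc(N)cc1` gives 0.8%, the lowest of the two numbers. Compound 2 `COc1ccc(/C=C/C(=O)c2ccc(O)cc2O)cc1Br` gives 73.2%, a number that lies far beyond the usual scatter above that of compound 1. Going by the values given here, the two compounds differ in more than one place, so their gap cannot be tied to any single change, and no step between them has been worked out.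

Compound 3 `COc1cc(O)ccc1/C=C/C(=O)c1ccc(F)cc1` has not yet been measured in this assay. It differs from compound 1 in one place only: fluoro in place of amino on an aromatic carbon. The change sits on an aromatic carbon of a six-membered aromatic ring of carbon only, para to a large group.

Compound 1 sits near the floor of what this assay reports, and a one-atom swap at a single aromatic carbon gives no ground, from the two numbers at hand, to expect a large move. The step from compound 1 to compound 3 is therefore expected to be a number 7.2 percentage points higher from compound 1 to compound 3 (within the scatter), within the scatter or at most a modest rise. Compound 3 is expected to give about 8%, estimated between 0% and 35%.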

Compound 3, a percentage reported as inhibition, at one concentration (the size of the read-out at that concentration, not a potency): 95.8%
Estimate against measurement, compound 3: 87.8 percentage points below; measured number outside the range, above it.
By their numbers in this assay, from the lowest: compound 1; then compound 2; then compound 3.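

In this assay, fluoro in place of amino on an aromatic carbon, para to a large group, gives a number 95 percentage points higher from compound 1 to compound 3 (beyond the scatter). The only earlier gap lay between compounds that differ in more than one place, whereas this step ties a large change in the read-out to a single position, with the rest of the core of compound 1 unchanged. The leaving amino counts one hydrogen-bond donor and one hydrogen-bond acceptor and the entering fluoro counts neither, but no measurement at hand gives a reason for the step.

The compounds shown do not separate what fluoro brings to this carbon from what the loss of amino removes, and a plain hydrogen, a chloro or a nitrile at the same carbon would help to tell those two apart. On these data alone, it also remains open whether the same exchange would give a step of similar size on a different core, as the step rests on this one pair of compounds.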